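This account rests on a few compounds, and the source may have more. Where it says the series, first, only, none or still open, it means among the compounds named here.

In a functional assay on HeLa cells (Homo sapiens) for inhibition, read by sulforhodamine B assay (on this read-out lower numbers stand for stronger inhibition and higher numbers for weaker inhibition), compound 1 `O=C1C(Nc2ccccc2)=CC(=O)c2c1nc1n2[C@H]2OC[C@@H](O)[C@H]2OC1` gives > 8000 nM, which is a limit of the assay and not a number. Compound 2 `CCc1ccc(NC2=CC(=O)c3c(nc4n3[C@H]3OC[C@@H](O)[C@H]3OC4)C2=O)cc1` gives 6510 nM, and compound 3 `Cc1ccc(NC2=CC(=O)c3c(nc4n3[C@H]3OC[C@@H](O)[C@H]3OC4)C2=O)cc1C` gives 4320 nM. These two cannot be told apart, with a 1.5-fold lower number from compound 2 to compound 3 (0.18 log units; within the scatter). The steps that start from the limit are an at least 1.2-fold lower number from compound 1 to compound 2 (0.08 log units; that floor lies within the scatter) and an at least 1.8-fold lower number from compound 1 to compound 3 (0.26 log units; that floor lies within the scatter), so all three compounds sit close together so far.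

Compound 4 `O=C1C(N2CCCC2)=CC(=O)c2c1nc1n2[C@H]2OC[C@@H](O)[C@H]2OC1` makes a larger change to compound 3: pyrrolidin-1-yl in place of (3,4-dimethylphenyl)amino on a double-bonded ring carbon. The measured steps only alter groups on the aromatic ring, and none of them removes that ring or the amine hydrogen. They therefore bear on this change only weakly, and the wide range reflects that. With compound 3 at 4320 nM and every measured step within the scatter, no step beyond the scatter is expected, though a drift towards a higher number seems likelier than the reverse. The expected step is a 1.4-fold higher number from compound 3 to compound 4 (0.14 log units; within the scatter). Compound 4 is estimated at 6000 nM, with an expected range of 1800 nM to 16000 nM.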

Compound 4, half-maximal inhibitory concentration: > 16000 nM
Compound 4: only a limit was reported (the forecaster's own chance of this, stated with the estimate: 35%); middle value at least 2.6-fold (0.42 log units) from the limit.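

Among the compounds shown here, replacing the whole group on the double-bonded ring carbon, rather than only altering the aromatic ring, gives the first steps beyond the scatter in this assay: there is an at least 3.7-fold higher number from compound 3 to compound 4 (0.56 log units; beyond the scatter), and there is an at least 2.4-fold higher number from compound 2 to compound 4 (0.39 log units; beyond the scatter). At this position, then, pyrrolidin-1-yl is not an equal replacement for (3,4-dimethylphenyl)amino or (4-ethylphenyl)amino, whereas the changes on the aromatic ring showed no step beyond the scatter. Compound 4 gives only a limit of the assay and not a number, so both steps are floors and their full size remains unknown: the limit of > 16000 nM in this assay, at which 1 of the 4 values shown sits.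

The step from compound 1 to compound 4 cannot be read. Going by these compounds, the aromatic ring and the amine hydrogen leave together in this change, and whether the weaker inhibition follows one or the other stays open; a cyclopentylamino group would keep the amine hydrogen without the aromatic ring.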